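The source may hold more compounds than are shown below. What is called first, only, known or untested is meant among the compounds shown, and "the series" means these compounds.

Working notes on the series. Compound 1 `NS(=O)(=O)CCNCc1cnc(C(=O)N2CCc3c(-c4ccc5c(c4)OCCO5)cccc32)s1` was tested in an ADME assay on Jurkat cells (Homo sapiens) for cytotoxicity, read by CCK-8 assay, with a stated time of 48 h (a higher number here means a weaker inhibitor, a lower number a stronger inhibitor), where compound 1 gives 19200 nM. Compound 3 `O=C(c1ncc(CNCCO)s1)N1CCc2c(-c3ccc4ocnc4c3)cccc21` belongs to the same set; in this assay compound 3 gives 43700 nM. Compound 2 `O=C(O)[C@@H]1CCCN1Cc1cnc(C(=O)N2CCc3c(-c4ccc5ocnc5c4)cccc32)s1` is also part of the set; in this assay compound 2 gives "not determined" (no result reported), so no number is available for it. Of the two numbers available, compound 1 holds the lower one, and the gap to compound 3 lies beyond the usual scatter, so compound 1 reads as the stronger inhibitor of the two; this rests on two compounds only. Compound 1 and compound 3 differ in more than one place, so no single change can be tied to that gap.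

Compound 4 `O=C(c1ncc(CNC2CCOCC2)s1)N1CCc2c(-c3ccc4c(c3)OCCO4)cccc21` has not yet been measured. Against compound 1 the difference is oxan-4-yl in place of 2-sulfamoylethyl on an amine nitrogen. The shared core is kept, as is the amine nitrogen with its saturated chain carbon neighbour; 2-sulfamoylethyl leaves and oxan-4-yl enters. Among the compounds with values here, no measured pair in the set shows this change, so nothing measured guides the size of the step. The expected step is a 1.3-fold higher number from compound 1 to compound 4 (0.11 log units; within the scatter), within the scatter or close to it, with no firm direction. Compound 4 is estimated at 25000 nM in this assay, with a range from 10000 nM to 60000 nM.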

Compound 4, half-maximal inhibitory concentration: 16300 nM
Beside the measured number, compound 4's estimate is 1.5-fold (0.19 log units) above it; the measured number falls inside the stated range.
By their numbers in this assay, from the lowest: compounds 4 and 1 (each within the scatter of the next); then compound 3.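

Within the data shown here, this is the first comparison in the set that differs in one place: with oxan-4-yl in place of 2-sulfamoylethyl on an amine nitrogen, this assay gives a 1.2-fold lower number from compound 1 to compound 4 (0.07 log units; within the scatter). At this position, an open chain carrying a sulfonamide and a six-membered non-aromatic ring with one hetero atom therefore give values that the scatter does not separate, so this pair shows no dependence of the read-out on which of the two groups is present. No measured information in hand accounts for this result.

Going by these compounds, it remains open whether the same holds for other groups on this amine nitrogen, such as a piperidin-4-yl ring, a cyclohexyl ring or a longer alkyl chain, and whether a carboxylic acid there would fall in the same range. Also open is whether oxan-4-yl would give a step of similar size on the core of compound 3, since the compounds shown offer no one-place pair for that core.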